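Ethyl for Methyl on the Acylsulfonamide: Expected Monkey Exposure

A few compounds are considered here, and "the series" means these few. Any claim that something is new, unique, unknown or untested is made for them only; others in the source may bear on it.

Compound 1: `Cc1sc(N(CC2CC2)[C@H](C)c2ccc(-c3cc(Cl)ccc3-c3nc(=O)o[nH]3)cc2)nc1C(=O)O` — 2210 ng.h/mL
Compound 2: `Cc1sc(N(CC2CC2)[C@H](C)c2ccc(-c3cc(Cl)ccc3-c3nc(=O)o[nH]3)cc2)nc1C(=O)NS(C)(=O)=O` — 726 ng.h/mL

Two compounds have so far been run in an ADME assay on the whole organism (Macaca fascicularis) for pharmacokinetics, at a dose of 1 mg/kg by the oral route; on this read-out higher numbers stand for higher exposure at the dose given and lower numbers for lower exposure. For the measured compounds named here, the only step between them that changes one place is a 3.0-fold lower number from compound 1 to compound 2 (0.48 log units; beyond the scatter), an exchange at the carbonyl carbon. On these two numbers compound 2 stands lowest; its nearest neighbour is compound 1, which lies higher by that same step, a gap beyond the scatter.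

Compound 3 `CCS(=O)(=O)NC(=O)c1nc(N(CC2CC2)[C@H](C)c2ccc(-c3cc(Cl)ccc3-c3nc(=O)o[nH]3)cc2)sc1C` differs from compound 2 by methyl in place of hydrogen on a saturated chain carbon bound to a sulfonyl sulfur. Going by the values given here, no measured step bears on this change: the one step on record concerns the group on the carbonyl carbon, not the saturated chain carbon bound to the sulfonyl sulfur, so there is nothing to carry over in either direction. In the absence of any comparable step, the exposure of compound 3 in this assay is expected to stay close to that of compound 2, with a step of a 1.1-fold lower number from compound 2 to compound 3 (0.05 log units; within the scatter) expected, which is within the scatter. The estimate for compound 3 in this assay is 650 ng.h/mL, with a range from 250 ng.h/mL to 1600 ng.h/mL.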

Compound 3, area under the concentration-time curve: 2170 ng.h/mL
Estimate against measurement, compound 3: 3.3-fold (0.52 log units) below, and the stated range ends below it.
By their numbers in this assay, from the lowest: compound 2; then compounds 3 and 1 (each within the scatter of the next).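

In this assay, the saturated chain carbon bound to the sulfonyl sulfur turns out to be a place that responds to a small change: going from methanesulfonamido to (ethylsulfonyl)amino, which adds 1 carbon, gives a 3.0-fold higher number from compound 2 to compound 3 (0.48 log units; beyond the scatter). The exchange at the carbonyl carbon therefore has no fixed cost in exposure: methanesulfonamido in place of hydroxy gave a 3.0-fold lower number from compound 1 to compound 2 (0.48 log units; beyond the scatter), whereas (ethylsulfonyl)amino in place of hydroxy gives a 1.0-fold lower number from compound 1 to compound 3 (0.01 log units; within the scatter), which leaves compound 3 and compound 1 within the scatter of each other. Nothing at hand bears on what lies behind the response to this added carbon.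

Going by these compounds, with only methyl and ethyl on the sulfonyl sulfur, it remains open whether the trend extends to a longer chain such as propyl, to a branched isopropyl group or to a cyclopropyl ring. For the compounds shown here, it is equally open how a terminal amine or a methoxy group on that chain would read in this assay, and whether the ethyl result would hold on a core other than the one shared by these compounds.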